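Adding one chloro to a series held at the limit

The compounds below may be only part of what the source reports. "The series", "measured", "known", "first", "only" and "open" are said of these compounds alone.

compound 1 `COc1cc(-n2ncnc2-c2ccc(Cl)c(Cl)c2)cc(OC)c1OC` gives > 10000 nM
compound 2 `COc1cc(-n2ncnc2-c2ccccc2)cc(OC)c1OC` gives > 10000 nM

In a functional assay on MCF7 cells (Homo sapiens) for antiproliferative activity, read by MTT assay, with a stated time of 72 h (on this read-out lower numbers stand for stronger inhibition and higher numbers for weaker inhibition), compound 2 gives > 10000 nM as a limit of the assay and not as a number. Among the compounds with values here, its position cannot be ranked, and the series so far stands at the limit of > 10000 nM in this assay, at which 2 of the 2 values shown sit.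

The next change, phenyl to 3-chlorophenyl, leads to compound 3 `COc1cc(-n2ncnc2-c2cccc(Cl)c2)cc(OC)c1OC` and places chloro in place of hydrogen on an aromatic carbon, meta to a large group: chloro in place of hydrogen on an aromatic carbon.

Within the data shown here, only one measured step bears on this change, a step that the two limits leave unreadable from compound 1 to compound 2, which puts phenyl in place of 3,4-dichlorophenyl. Its size cannot be read, so it offers no measured effect to carry over.

Compound 1 carries two chloro groups and gives > 10000 nM, which is also a limit. On that basis, no step beyond the scatter is expected in this assay, and a clear gain in either direction has no support.

The expected step is a step that the limit leaves unreadable from compound 2 to compound 3, an estimate that is largely bound by the limit.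

For compound 3 the estimated value is 15000 nM, with an expected range from 6000 nM to 40000 nM, and a report as a limit is the likeliest outcome.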

Compound 3, half-maximal inhibitory concentration: > 10000 nM
Compound 3: no number, only a limit (the forecaster's own chance of this, stated with the estimate: 75%); the middle value lies beyond the limit too.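

Compound 1, compound 2 and compound 3 are all reported as limits in this assay, so no step among them can be read, and the series stands at: the limit of > 10000 nM in this assay, at which 3 of the 3 values shown sit.

The compounds shown leave open whether any change to the phenyl group of compound 2 gives a readable value in this assay.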